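Trading a dichlorophenoxy group for a fluorophenoxy group

This account rests on a few compounds, and the source may have more. Where it says the series, first, only, none or still open, it means among the compounds named here.

Compound 1 `Nc1cc(N)c2nc(-c3ccccc3)c(Oc3ccc(Cl)c(Cl)c3)nc2c1` is one of three compounds built on a shared core. In a functional assay on RPMI8266 cells (Homo sapiens) for inhibition, read by sulforhodamine B assay, with a stated time of 48 h (on this read-out lower numbers stand for stronger inhibition of growth and higher numbers for weaker inhibition of growth), compound 1 gives 3470 nM, which places it between the other two. Compound 3 `COc1cc(CNc2nc3cc(N)cc(N)c3nc2-c2ccccc2)cc(OC)c1OC` gives 692 nM in this assay, a stronger result than compound 1 that lies beyond the scatter. Compound 2 `CCOC(=O)[C@H](CCC(=O)O)NC(=O)c1ccc(CNc2nc3cc(N)cc(N)c3nc2-c2ccccc2)cc1` gives 28200 nM, weaker than compound 1, again beyond the scatter. Compound 4 `Nc1cc(N)c2nc(-c3ccccc3)c(Oc3ccc(F)cc3)nc2c1` has not yet been measured; it differs from compound 1 by 4-fluorophenyl in place of 3,4-dichlorophenyl on an oxygen on an aromatic ring. Among the compounds with values here, no measured pair shows this same change, so its effect is not known from the data. A modest weakening, near the edge of the scatter, is expected, a 1.6-fold higher number from compound 1 to compound 4 (0.20 log units; within the scatter). Compound 4 is therefore estimated at 5500 nM, with a range from 1500 nM to 20000 nM.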

Compound 4, concentration for 50% growth inhibition: 12300 nM
Compound 4: middle estimate off by 2.2-fold (0.35 log units), on the low side; low and high end bracket the measured number.
By their numbers in this assay, from the lowest: compound 3; then compound 1; then compound 4; then compound 2.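

In this assay, 4-fluorophenyl in place of 3,4-dichlorophenyl on the oxygen gives a 3.5-fold higher number from compound 1 to compound 4 (0.55 log units; beyond the scatter). Within the data shown here, this is the first single-place comparison in the set, and it shows that growth inhibition responds to what the phenyl ring on this oxygen carries. Nothing measured here explains the loss.

Going by these compounds, it remains open whether the two chlorines act together or one alone accounts for the difference, which a phenyl ring carrying a single chlorine would test. A plain phenyl group on the same oxygen would show how either halogen pattern compares with no halogen at all.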